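This account rests on a few compounds, and the source may have more. Where it says the series, first, only, none or still open, it means among the compounds named here.

Values in a functional assay on the whole organism with Mus musculus as the target; on this read-out lower numbers stand for an effect already at smaller amounts and higher numbers for an effect only at larger amounts of compound:
- compound 1 `NC(=O)/C=C1\CCc2cc(F)cc(F)c21`: 44 mg/kg
- compound 2 `NC(=O)/C=C1\CCc2cc(F)c(F)cc21`: 64 mg/kg
- compound 3 `O=C(/C=C1\CCc2cc(F)ccc21)NC1CC1`: 81 mg/kg

Compound 3 at 81 mg/kg lies within the scatter of both compound 1 and compound 2. The next compound is compound 4 `NC(=O)/C=C1\CCc2cc(F)ccc21`, with hydrogen in place of cyclopropyl on an amide-type nitrogen. Going by the values given here, no pair of measured compounds isolates this change, so its size in this assay has no direct precedent. Compound 1 at 44 mg/kg and compound 2 at 64 mg/kg also carry hydrogen on that nitrogen, and neither separates from compound 3 beyond the scatter. The expected change is therefore a 1.5-fold lower number from compound 3 to compound 4 (0.17 log units; within the scatter), with no step beyond the scatter. Compound 4 is estimated at 55 mg/kg, with an expected range of 28 mg/kg to 110 mg/kg.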

Compound 4, dose for half-maximal effect: 56 mg/kg
Beside the measured number, compound 4's estimate is 1.0-fold (0.01 log units) below it; measured number inside the range.
By their numbers in this assay, from the lowest: compounds 1, 4, 2 and 3 (each within the scatter of the next).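

In this assay, going by these compounds alone, the first direct reading of hydrogen in place of cyclopropyl on an amide-type nitrogen is a 1.4-fold lower number from compound 3 to compound 4 (0.16 log units; within the scatter) and stays inside the scatter, so this nitrogen tolerates either group here. Hydrogen in place of fluoro on an aromatic carbon also gives no separation, with a 1.1-fold lower number from compound 2 to compound 4 (0.06 log units; within the scatter) and a 1.3-fold higher number from compound 1 to compound 4 (0.10 log units; within the scatter) as its two readings. Nothing measured here offers an explanation for these steps.
Still open, as far as these compounds go, is whether any change at the nitrogen moves the number beyond the scatter, for instance a longer chain such as n-butyl. A carboxylic acid in place of the primary amide is equally untested in this set of compounds.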